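Ester variation at the free hydroxyl of a shared core

The source may report more compounds than this note shows. Statements on the series, on what has been measured and on what is new or still open speak of the compounds shown alone.

Measured so far in an ADME assay on a cell-free system (plasma, Homo sapiens) for metabolic stability, with Plasma (Rattus norvegicus) as the target, read by HPLC, at pH 7.4; a lower number here means that the compound disappears faster, a higher number that the compound lasts longer:
compound 1, `CC(=O)Oc1ccccc1C(=O)O[C@H]1CO[C@H]2[C@@H]1OC[C@H]2O` — 0.0183 h
compound 2, `CC(=O)Oc1ccccc1C(=O)O[C@H]1CO[C@H]2[C@@H]1OC[C@H]2OC(C)=O` — 0.0095 h
compound 3, `COc1cccc(C(=O)O[C@@H]2CO[C@H]3[C@@H]2OC[C@@H]3OC(=O)c2ccccc2OC(C)=O)c1` — 0.0142 h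

Compound 1 carries the free hydroxyl on the shared core and gives the top number of the three, but the gaps to the others are small: a 1.3-fold lower number from compound 1 to compound 3 (0.11 log units; within the scatter) and a 1.9-fold lower number from compound 1 to compound 2 (0.28 log units; within the scatter). The two esters also sit close to each other, a 1.5-fold higher number from compound 2 to compound 3 (0.17 log units; within the scatter). Within these three compounds, capping the hydroxyl with either an acetyl or a (3-methoxyphenyl)carbonyl group has not moved the half-life beyond the scatter.

Compound 4, `CC(=O)Oc1ccccc1C(=O)O[C@H]1CO[C@H]2[C@@H]1OC[C@H]2OC(=O)c1ccc([N+](=O)[O-])cc1`, is the next member and has not yet been measured. Relative to compound 1 it differs thus: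
(4-nitrophenyl)carbonyl in place of hydrogen on an oxygen on a saturated carbon

The relevant steps are the two earlier acylations of the same oxygen. Both pointed slightly downward and both stayed within the scatter. No (4-nitrophenyl)carbonyl ester has been measured in this series, so the expectation rests on those two steps alone: a small downward shift in this assay, or none beyond the scatter. For compound 4 the half-life is expected to be about 0.013 h, with a range of 0.006 h to 0.03 h, which is estimated as a step of a 1.4-fold lower number from compound 1 to compound 4 (0.15 log units; within the scatter).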

Compound 4, half-life: 0.0227 h
For compound 4 the middle estimate is 1.7-fold (0.24 log units) below the measured one, within the range that was stated.
By their numbers in this assay, from the lowest: compounds 2, 3, 1 and 4 (each within the scatter of the next, the first and the last beyond it).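

In this assay, the (4-nitrophenyl)carbonyl group on this oxygen stays level with the free hydroxyl, with a 1.2-fold higher number from compound 1 to compound 4 (0.09 log units; within the scatter) as the step, and level with the other aromatic ester, with a 1.6-fold higher number from compound 3 to compound 4 (0.20 log units; within the scatter) as the step. Within the data shown here, exchanging methyl on the carbonyl carbon for 4-nitrophenyl gives the first step beyond the scatter, though a modest one, at a 2.4-fold higher number from compound 2 to compound 4 (0.38 log units; beyond the scatter), which shows that the choice of ester at this oxygen can register in the half-life, at least between these two compounds. Nothing available here accounts for that step.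

Open, going by these compounds, is whether the step rests on the aromatic ring or on its nitro group: compound 3, with its 3-methoxyphenyl group, lies within the scatter of both compound 2 and compound 4, and a plain phenylcarbonyl group would bear on the question. Also open, on these data alone, is how this oxygen behaves with a link other than an ester, such as a carbamate or an ether carrying a longer chain.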